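The compounds below may be only part of what the source reports. "The series", "measured", "known", "first", "only" and "open" are said of these compounds alone.

Measured so far:
- compound 1, `O=C(Nc1ccccc1C(F)(F)F)c1ccc2ccccc2n1`: > 90000 nM
- compound 2, `O=C(Nc1cc(C(F)(F)F)cc(C(F)(F)F)c1)C1CCc2ccccc2N1C(=O)c1ccc(Cl)cc1`: 889 nM
- compound 3, `O=C(Nc1cc(C(F)(F)F)cc(C(F)(F)F)c1)c1ccc2ccccc2n1`: 1440 nM

All three were tested in a functional assay on NCI-H23 cells (Homo sapiens) for cytotoxicity, read by sulforhodamine B assay, with a stated time of 72 h; on this read-out higher numbers stand for weaker inhibition of growth and lower numbers for stronger inhibition of growth. Among the compounds with values here, for compound 1 the result is only a limit of the assay, > 90000 nM, not a number; it is the one value that sits at the limit of > 90000 nM in this assay, at which 1 of the 3 values shown sits. Compound 2 gives 889 nM and compound 3 gives 1440 nM, and these two numbers lie within the usual scatter of each other, so no order between compound 2 and compound 3 can be claimed. Within the data shown here, compound 2 is thus one of the two numbers on record, and the only one whose core carries an acyl group on the ring nitrogen.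

Compound 4, `CCCCCCCCC(=O)N1c2ccccc2CCC1C(=O)Nc1cc(C(F)(F)F)cc(C(F)(F)F)c1`, has not yet been tested. It differs from compound 2 in one place: octyl in place of 4-chlorophenyl on a carbonyl carbon. The octyl takes the place of the 4-chlorophenyl on a carbonyl carbon whose other neighbour is an amide-type nitrogen in a ring.

Among the measured compounds shown here, no measured pair shows what such a change does here, so the expectation rests on compound 2 alone. The step of a 2.0-fold higher number from compound 2 to compound 4 (0.31 log units; beyond the scatter) is expected to be small, toward weaker inhibition of growth, and may well fall within the scatter. Compound 4 is therefore estimated at 1800 nM, with a likely range from 500 nM to 6000 nM.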

Compound 4, concentration for 50% growth inhibition: 3230 nM
Beside the measured number, compound 4's estimate is 1.8-fold (0.25 log units) below it; the measured number falls inside the stated range.
By their numbers in this assay, from the lowest: compounds 2 and 3 (each within the scatter of the next); then compound 4. At a limit, above all of these: compound 1.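

In this assay, the change of octyl in place of 4-chlorophenyl on a carbonyl carbon now has a measured size: a 3.6-fold higher number from compound 2 to compound 4 (0.56 log units; beyond the scatter) is a modest step, yet one beyond the scatter. Within the data shown here, the earlier compounds included only one with an acyl group on the ring nitrogen, so they could not show whether the group on this carbonyl affects the read-out; this pair shows that it does, with weaker inhibition of growth on going to octyl. The same pair also shows that the ring is not essential at this position, as compound 4, with no ring in this group, still gives 3230 nM, although one pair cannot establish a general trend, and nothing measured here explains the direction of the step.

From the compounds shown here alone, it remains open whether a shorter chain such as butyl, a chain ending in an amine or a carboxylic acid, or a plain phenyl without the chlorine would give numbers nearer to compound 2 or to compound 4. Going by these compounds, it also remains open whether the same change would have a similar effect with another aryl group on the amide nitrogen.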